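Catechol for Benzyl at the Ether Oxygen

The source may report more compounds than this note shows. Statements on the series, on what has been measured and on what is new or still open speak of the compounds shown alone.

Compound 2 `O=C(NCCNS(=O)(=O)c1ccc(-c2ccccc2OCc2ccccc2)s1)Nc1cc(C(F)(F)F)cc(C(F)(F)F)c1` was tested in a functional assay on RS4-11 cells (Homo sapiens) for inhibition, read by CCK-8 assay, with a stated time of 48 h; a higher number here means a weaker inhibitor, a lower number a stronger inhibitor. In this assay compound 2 gave only a limit, > 50000 nM, and no number. Compound 1 `COc1ccc(Oc2ccccc2-c2ccsc2S(=O)(=O)N2CCN(C(=S)Nc3cc(C(F)(F)F)cc(C(F)(F)F)c3)CC2)cc1OC` likewise gave only a limit in this assay, > 50000 nM. Compound 3 `CC(C)c1ccc(Oc2ccc(O)c(O)c2)c(-c2ccsc2S(=O)(=O)NCCNC(=S)Nc2cc(C(F)(F)F)cc(C(F)(F)F)c2)c1`, which carries a 3,4-dihydroxyphenoxy group, gave 3700 nM in this assay. Thus two of the three values sit at a limit (the limit of > 50000 nM in this assay, at which 2 of the 3 values shown sit). Compound 4 `O=C(NCCNS(=O)(=O)c1ccc(-c2ccccc2Oc2ccc(O)c(O)c2)s1)Nc1cc(C(F)(F)F)cc(C(F)(F)F)c1` is not yet measured; it differs from compound 2 in one place: 3,4-dihydroxyphenyl in place of benzyl on an oxygen on an aromatic ring. Because compound 3 gives 3700 nM in this assay with the same 3,4-dihydroxyphenoxy group, compound 4 is expected to inhibit more strongly than compound 2, an expected step of an at least 5.0-fold lower number from compound 2 to compound 4 (0.69 log units; beyond the scatter). Compound 4 is estimated at 10000 nM in this assay, within a range of 2000 nM to 50000 nM.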

Compound 4, half-maximal inhibitory concentration: 4900 nM
Compound 4: the middle estimate sits 2.0-fold (0.31 log units) above what was measured; the range from low to high includes it.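

In this assay, putting 3,4-dihydroxyphenyl in place of benzyl on this oxygen gives an at least 10-fold lower number from compound 2 to compound 4 (1.00 log units; beyond the scatter). This is the first pair shown that differs in one place only, so the gain in inhibition can be tied to this single change on the shared core. The full size of the step stays unknown because compound 2 gave only a limit, not a number: the limit of > 50000 nM in this assay, at which 2 of the 4 values shown sit.

The compounds shown leave open whether the gain needs both hydroxyl groups. A plain phenyl, or a phenyl carrying a single hydroxyl, on the same oxygen might do as well.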